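The compounds below may be only part of what the source reports. "The series", "measured", "known", "first", "only" and "open" are said of these compounds alone.

Three compounds have been measured in a functional assay on the whole organism (aorta) with Rattus norvegicus as the target; a higher number here means a larger maximal response, a lower number a smaller maximal response:

Compound 1 `CNS(=O)(=O)c1ccc2c(c1)C(n1ccccc1=O)=CC(C)(C)O2`: 85.8%
Compound 2 `CCNS(=O)(=O)c1ccc2c(c1)C(n1ccccc1=O)=CC(C)(C)O2`: 72.4%
Compound 3 `CC1(C)C=C(n2ccccc2=O)c2cc(S(=O)(=O)Nc3ccc([N+](=O)[O-])cc3)ccc2O1`: 82.2%

Compound 3 stands in the middle of the three numbers, but neither gap is meaningful: a number 3.6 percentage points lower from compound 1 to compound 3 (within the scatter) and a number 9.8 percentage points higher from compound 2 to compound 3 (within the scatter). Compound 4 `CC1(C)C=C(n2ccccc2=O)c2cc(S(=O)(=O)N3CCOCC3)ccc2O1` differs from compound 3 in one place: morpholin-4-yl in place of (4-nitrophenyl)amino on a sulfonyl sulfur. All three measured steps change the group on the sulfonamide nitrogen. Only a number 13.4 percentage points lower from compound 1 to compound 2 (beyond the scatter) is beyond the scatter, and it is modest; the other two are within the scatter. None of them removes the hydrogen-bond donor, so the data give no direct guide to that part of the change. A small step or none beyond the scatter is therefore expected: a number 4.2 percentage points lower from compound 3 to compound 4 (within the scatter). Compound 4 is estimated at 78%, between 62% and 92%.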

Compound 4, largest response reached (Emax), in percent of the reference or control that the assay uses: 75.5%
For compound 4 the middle estimate is 2.5 percentage points above the measured one; the range from low to high includes it.
By their numbers in this assay, from the lowest: compounds 2, 4, 3 and 1 (each within the scatter of the next, the first and the last beyond it).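

Morpholin-4-yl on the sulfonyl sulfur brings 0 hydrogen-bond donors, and the steps to compound 4 are a number 6.7 percentage points lower from compound 3 to compound 4 (within the scatter) and a number 3.1 percentage points higher from compound 2 to compound 4 (within the scatter), with only a number 10.3 percentage points lower from compound 1 to compound 4 (beyond the scatter) as a modest change. Among these compounds, then, a large maximal response does not depend on a hydrogen-bond donor at this place, and a ring can stand there in place of an open amino group. Nothing available here explains these steps.

From the compounds shown here alone, what remains open is how piperidin-1-yl, which has no ring oxygen, would compare with morpholin-4-yl, and so whether that oxygen matters.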